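Triazole aryl swap: from compound 3 to compound 4

The compounds below may be only part of what the source reports. "The series", "measured", "known", "first", "only" and "open" are said of these compounds alone.

Compound 3 `O=C1O[C@H]([C@@H](O)Cn2cc(-c3cc(F)cc(F)c3)nn2)C(OCc2ccccc2)=C1OCc1ccccc1` gives 40800 nM in a functional assay on HeLa cells (Homo sapiens) for antiproliferative activity, read by MTT assay, with a stated time of 72 h (a higher number here means a weaker inhibitor, a lower number a stronger inhibitor), the higher of the two numbers in hand, with compound 1 `O=C1O[C@H]([C@@H](O)Cn2cc(-c3cccc(O)c3)nn2)C(OCc2ccccc2)=C1OCc1ccccc1` nearest at 39300 nM; the gap between them, a 1.0-fold higher number from compound 1 to compound 3 (0.02 log units; within the scatter), sits within the scatter, so the two are treated as equivalent. Compound 2 `COc1ccccc1-c1cn(C[C@H](O)[C@H]2OC(=O)C(OCc3ccccc3)=C2OCc2ccccc2)nn1` reports the limit > 100000 nM in this assay, a limit and not a number (the limit of > 100000 nM in this assay, at which 1 of the 3 values shown sits).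

Compound 4 `COc1ccc(-c2cn(C[C@H](O)[C@H]3OC(=O)C(OCc4ccccc4)=C3OCc3ccccc3)nn2)cc1` differs from compound 3 in one place: 4-methoxyphenyl in place of 3,5-difluorophenyl on an aromatic carbon. Going by the values given here, two measured steps bear on this change. The step of an at least 2.4-fold lower number from compound 2 to compound 3 (0.38 log units; beyond the scatter) removes a methoxyphenyl in favour of the difluorophenyl and lowers the number at least modestly; compound 4 runs that exchange in reverse, with the methoxy group now on the 4-methoxyphenyl rather than the 2-methoxyphenyl. The step of a 1.0-fold higher number from compound 1 to compound 3 (0.02 log units; within the scatter) shows the difluorophenyl and the 3-hydroxyphenyl giving the same number within the scatter. On this basis a modest rise in the number is expected for compound 4 in this assay, with a real chance that only a limit is returned again.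

Compound 4 is estimated at 75000 nM, between 30000 nM and 160000 nM, which means an expected step of a 1.8-fold higher number from compound 3 to compound 4 (0.26 log units; within the scatter).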

Compound 4, half-maximal inhibitory concentration: 16400 nM
Beside the measured number, compound 4's estimate is 4.6-fold (0.66 log units) above it, outside the stated range (below it).
By their numbers in this assay, from the lowest: compound 4; then compounds 1 and 3 (each within the scatter of the next). At a limit, above all of these: compound 2.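

In this assay a methoxy group on this aryl ring is no liability in itself: the 4-methoxyphenyl gives a 2.5-fold lower number from compound 3 to compound 4 (0.40 log units; beyond the scatter) and a 2.4-fold lower number from compound 1 to compound 4 (0.38 log units; beyond the scatter), so the 3,5-difluorophenyl and 3-hydroxyphenyl, which could not be told apart, both now read as weaker than this group. The earlier compounds suggested that methoxy costs activity, but that reading held only for the 2-methoxyphenyl, since moving the methoxy group around the ring gives an at least 6.0-fold lower number from compound 2 to compound 4 (0.78 log units; beyond the scatter), which makes the arrangement on the aryl ring, and not the mere presence of methoxy, the variable that matters among these compounds. The size of that step is open-ended, as compound 2 is held at a limit and not a number: the limit of > 100000 nM in this assay, at which 1 of the 4 values shown sits.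

The compounds shown leave open whether the lower number of the 4-methoxyphenyl needs the oxygen at all; a 4-methylphenyl, a 4-hydroxyphenyl or a 4-ethoxyphenyl on the same core would separate these readings. They also give no reason for the lower number, and with only this one cell line they say nothing on whether the step carries over to other cells.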